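The source may hold more compounds than are shown below. What is called first, only, known or untested is meant among the compounds shown, and "the series" means these compounds.

Measured compounds:
compound 1 `CC1(OC(=O)N2C[C@H]3COC[C@@H](C2)[C@@H]3Oc2ncnc(Nc3ccccc3F)c2F)CC1` gives 25 nM in a functional assay for agonist activity at Glucose-dependent insulinotropic receptor (Mus musculus), read by cAMP accumulation; a higher number here means that more compound is needed for the effect, a lower number that less compound is needed
compound 2 `N#Cc1ccc(Nc2ncnc(OC3C4COCC3CN(C(=O)OC3CCC3)C4)c2F)c(Cl)c1` gives 60 nM in this assay
compound 3 `COc1c(Nc2ccc(S(C)(=O)=O)cc2F)ncnc1OC1C[C@@H]2COC[C@@H](C1)N2C(=O)OC1(C)CC1` gives 0.427 nM in this assay

Compound 2 carries the highest number of the three in this assay; compound 1 is nearest to it, and compound 3 lies furthest away, both beyond the scatter. Compound 4 `CC1(COC(=O)N2CC3COCC(C2)C3Oc2ncnc(Nc3ccc(C#N)cc3Cl)c2F)COC1` has not been measured. It differs from compound 2 in one place: (3-methyloxetan-3-yl)methyl in place of cyclobutyl on an oxygen next to a carbonyl group. Among the compounds with values here, no pair of measured compounds shows this change, so the size of its step is not known from the set. A small step is expected in this assay, in either direction or none beyond the scatter. Compound 4 is therefore estimated at 50 nM, within 15 nM to 160 nM, which means an expected step of a 1.2-fold lower number from compound 2 to compound 4 (0.08 log units; within the scatter).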

Compound 4, half-maximal effective concentration: 516 nM
Beside the measured number, compound 4's estimate is 10-fold (1.01 log units) below it, outside the stated range (above it).
By their numbers in this assay, from the lowest: compound 3; then compound 1; then compound 2; then compound 4.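

The group on an oxygen next to a carbonyl group is not a neutral choice in this assay: (3-methyloxetan-3-yl)methyl in place of cyclobutyl gives an 8.6-fold higher number from compound 2 to compound 4 (0.93 log units; beyond the scatter). Within the data shown here, this is the first single-place comparison, and it shows that the number responds to changes at this position. No available measurement bears on the reason for this step. Still open, going by these compounds, is whether the ring oxygen or the larger group accounts for the step. An oxetan-3-yl or cyclobutylmethyl group on the same oxygen would separate the two.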